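A few compounds are considered here, and "the series" means these few. Any claim that something is new, unique, unknown or untested is made for them only; others in the source may bear on it.

Compound 3 `CON(C)C(=O)[C@H]1CC=C(CCC=C(C)C)C[C@@H]1c1ccccc1` is the anchor of this set. In an assay on isolated protein for inhibition of Apoptosis regulator Bcl-2 (Homo sapiens), read by fluorescence polarization, with stated times of 5 min and 10 min (a lower number here means a stronger inhibitor, a higher number a weaker inhibitor), compound 3 gives 300 nM, the lowest of the three numbers recorded. Within the data shown here, compound 1 `CC(C)=CCCC1=CC[C@H](C(=O)N(C)O)[C@@H](c2ccccc2)C1` gives 2100 nM in this assay, and the one measured step at the carbonyl, a 7.0-fold lower number from compound 1 to compound 3 (0.85 log units; beyond the scatter), shows methyl in place of hydrogen on an oxygen is worth a modest but real gain. Among the measured compounds shown here, compound 2 `CC(C)=CCCC1=CC[C@@H](C(=O)Nc2ccc(C(=O)O)cc2)[C@H](c2ccccc2)C1` gives 2200 nM in this assay; it carries the same (4-carboxyphenyl)amino amide that compound 4 will carry, but no step connects it to the other compounds, so its value can only be set beside theirs.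

Compound 4 `CC(C)=CCCC1=CC[C@H](C(=O)Nc2ccc(C(=O)O)cc2)[C@@H](c2ccccc2)C1` differs from compound 3 in one place: (4-carboxyphenyl)amino in place of methoxy(methyl)amino on a carbonyl carbon. For the measured compounds named here, no measured step covers this exchange directly. Going by the values given here, the only step that bears on it, that from compound 1 to compound 3, is a change on the same carbonyl and was modest; the present change is much larger in what it removes and adds. Given that compound 2 gives 2200 nM with the same entering group, compound 3 is expected to lose ground to compound 4 by a 5.0-fold higher number from compound 3 to compound 4 (0.70 log units; beyond the scatter). Compound 4 is therefore estimated at 1500 nM, within 400 nM to 6000 nM.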

Compound 4, inhibition constant: > 23000 nM
Compound 4 gave a limit, no number; the forecaster's own chance of this, stated with the estimate: 5%; at least 15-fold (1.18 log units) between middle value and limit.
By their numbers in this assay, from the lowest: compound 3; then compounds 1 and 2 (each within the scatter of the next). At a limit, above all of these: compound 4.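

Among these compounds, the exchange on this carbonyl carbon costs far more than the earlier change there: an at least 76-fold higher number from compound 3 to compound 4 (1.88 log units; beyond the scatter), and likewise an at least 10-fold higher number from compound 1 to compound 4 (1.03 log units; beyond the scatter), while the only earlier step at this carbonyl carbon was the gain of a 7.0-fold lower number from compound 1 to compound 3 (0.85 log units; beyond the scatter). The (4-carboxyphenyl)amino group does not set the outcome alone, since its effect differs sharply with the configuration of the shared core, with an at least 10-fold higher number from compound 2 to compound 4 (1.01 log units; beyond the scatter): the fact that compounds 2 and 4 differ only in the configuration as drawn. In this assay compound 4 gives only a limit and not a number, so each of these steps has a lower bound and no fixed size: the limit of > 23000 nM in this assay, at which 1 of the 4 values shown sits.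

The compounds shown leave open whether the aromatic ring or the carboxylic acid of the entering group accounts for the loss relative to methoxy(methyl)amino, a question that a plain phenylamino group or a methyl ester in place of the acid would address. On these data alone, it also stays open whether the mirror image of compound 3 would show a comparable dependence on configuration with methoxy(methyl)amino on the carbonyl carbon.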